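This account rests on a few compounds, and the source may have more. Where it says the series, first, only, none or still open, it means among the compounds named here.

Among the measured compounds shown here, compound 1 `Cc1ccc(-c2cc(N3CCC(CNS(N)(=O)=O)CC3)ncn2)cc1` stands at the weak end of the two numbers so far: in a functional assay on M21 cells (Homo sapiens) for antiproliferative activity, read by sulforhodamine B assay, with a stated time of 48 h (a lower number here means a stronger inhibitor of growth, a higher number a weaker inhibitor of growth), compound 1 gives 71000 nM, while compound 2 `CCOC(=O)c1ccc(-c2cc(N3CCC(CNS(N)(=O)=O)CC3)ncn2)cc1` gives 5000 nM. For the measured compounds named here, the one step bearing on the aryl group is a 14-fold lower number from compound 1 to compound 2 (1.15 log units; beyond the scatter), which shows that changing a substituent on this ring can move the number a long way. Compound 3 `COc1ccccc1-c1cc(N2CCC(CNS(N)(=O)=O)CC2)ncn1` carries a different change at the same place: 2-methoxyphenyl in place of 4-methylphenyl on an aromatic carbon. Going by the values given here, no measured step tests a methoxy, so the direction is uncertain; a moderate gain is expected, a 2.4-fold lower number from compound 1 to compound 3 (0.37 log units; beyond the scatter). Compound 3 is estimated at 30000 nM, within 8000 nM to 100000 nM.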

Compound 3, concentration for 50% growth inhibition: > 100000 nM
Compound 3: no number, only a limit; the forecaster's own chance of this, stated with the estimate: 10%; at least 3.3-fold (0.52 log units) between middle value and limit.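

Compound 3 gives no number in this assay, only a limit: > 100000 nM. The change to 2-methoxyphenyl gives an at least 1.4-fold higher number from compound 1 to compound 3 (0.14 log units; that floor lies within the scatter), so this aryl swap brings no measurable gain, and the size of any loss cannot be read. Among the changes so far, only ethoxycarbonyl lowers the number, with a 14-fold lower number from compound 1 to compound 2 (1.15 log units; beyond the scatter).

On these data alone, it remains open whether 4-methoxyphenyl would behave like 2-methoxyphenyl, which would separate the effect of the group from that of its place on the ring. As far as these compounds go, it is also open whether a carboxylic acid or a primary amide in place of the ethoxycarbonyl would keep the lower number of compound 2.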